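A few compounds are considered here, and "the series" means these few. Any claim that something is new, unique, unknown or untested is made for them only; others in the source may bear on it.

Measured compounds in a physicochemical assay for lipophilicity, read by HPLC, tested at 5 mM; a lower number here means a more polar compound, a higher number a more lipophilic compound:

compound 1, `COC(=O)c1ccc(-c2nnn(CC(=O)C(C)Oc3ccc(Oc4ccc(F)cc4)cc3)n2)cc1`, 5.4
compound 2, `COC(=O)c1ccc(-c2nnn(CC(=O)C(C)Oc3ccc(Oc4ccc(Cl)cc4)cc3)n2)cc1`, 6.1
compound 3, `COC(=O)c1ccc(-c2nnn(CC(=O)C(C)Oc3ccc(-c4ccccc4)cc3)n2)cc1`, 5.4

Compound 2 stands highest of the three in this assay. The measured steps show a number 0.70 log units higher from compound 1 to compound 2 (beyond the scatter) and a number 0.70 log units lower from compound 2 to compound 3 (beyond the scatter), whereas no change at the digits printed from compound 1 to compound 3 (within the scatter). All three of these changes concern the outer aromatic tail of the shared core: fluoro, chloro, and the swap of a 4-fluorophenoxy or 4-chlorophenoxy group for phenyl.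

Compound 4, `CC(Oc1ccc(Oc2ccc(Cl)cc2)cc1)C(=O)Cn1nnc(-c2ccc(C(=O)O)cc2)n1`, differs from compound 2 in a different place: hydrogen in place of methyl on an oxygen next to a carbonyl group, which read one bond further out is methoxycarbonyl to carboxy. Among the compounds with values here, none of the measured steps touches this part of the molecule, so none of them gives a direct yardstick for this change; the three measured numbers only fix where compound 2 starts. The expectation therefore rests on the structural change itself, and it is a decrease in this assay that lies well beyond the scatter, a number 2.50 log units lower from compound 2 to compound 4 (beyond the scatter). The estimate for compound 4 in this assay is 3.6, with a likely range from 2.6 to 4.6.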

Compound 4, partition coefficient: 3.3
Beside the measured number, compound 4's estimate is 0.30 log units above it; the measured number falls inside the stated range.
By their numbers in this assay, from the lowest: compound 4; then compounds 1 and 3 (each within the scatter of the next); then compound 2.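

In this assay, the exchange of methoxycarbonyl for carboxy gives a number 2.80 log units lower from compound 2 to compound 4 (beyond the scatter) and is a large step, whereas the change from fluoro to chloro gives a number 0.70 log units higher from compound 1 to compound 2 (beyond the scatter) and is only modest. This position, hydrogen in place of methyl on an oxygen next to a carbonyl group, was not varied among the earlier compounds, and it now produces the biggest shift among the compounds shown, even though only a single heavy atom, the methyl carbon, leaves. Nothing measured here gives a reason for the size of this step.

Compound 4 is the only compound shown with a 4-carboxyphenyl group, and it carries the 4-chlorophenoxy tail, so it remains open whether the same exchange would give a step of similar size with the 4-fluorophenoxy tail of compound 1 or the phenyl tail of compound 3. On these data alone, it also remains open where an amide or a hydroxymethyl group in this place would fall relative to compound 2 and compound 4.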